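The source may hold more compounds than are shown below. What is called first, only, known or untested is meant among the compounds shown, and "the series" means these compounds.

Measured so far in an assay for inhibition of Tryptophan 2,3-dioxygenase (Homo sapiens), with a stated time of 1 h, tested at 10 uM; a higher number here means more inhibition at the concentration tested (going by the name of the read-out), a lower number less inhibition:

- compound 1, `OCc1ccc(CNc2cc(Br)cc3[nH]ncc23)cc1`: 56%
- compound 2, `Nc1cc(CNc2cc(Br)cc3[nH]ncc23)ccc1O`: "not active" (no number reported) (no number reported)
- compound 3, `Brc1cc(NCc2ccco2)c2cn[nH]c2c1`: 64%

Compound 3 holds the highest of the two numbers in this assay, but the number for compound 1 sits close to it, within the usual scatter of repeated measurements, so the two cannot be ordered. Going by the values given here, compound 2 is the one entry without a number. Among the compounds with values here, no single-change steps between measured compounds are available, so nothing in the measured set says how a swap at the chain carbon bound to the ring nitrogen moves the read-out.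

Compound 4, `Brc1cc(NCc2cnc[nH]2)c2cn[nH]c2c1`, is not yet measured in this assay. It differs from compound 3 by 1H-imidazol-5-yl in place of furan-2-yl on a saturated chain carbon bound to a nitrogen on an aromatic ring. Within the data shown here, with no measured step to lean on, the expectation is a small step from compound 3 to compound 4, most likely none beyond the scatter, with the downward side somewhat more probable than the upward. Compound 4 is expected to give about 52% in this assay, within 30% to 72%, which means an expected step of a number 12 percentage points lower from compound 3 to compound 4 (beyond the scatter).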

Compound 4, a percentage reported as inhibition, at one concentration (the size of the read-out at that concentration, not a potency): 54%
Compound 4: the middle estimate sits 2 percentage points below what was measured; measured number inside the range.
By their numbers in this assay, from the lowest: compounds 4, 1 and 3 (each within the scatter of the next).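

In this assay, going by these compounds alone, the swap of furan-2-yl for 1H-imidazol-5-yl on a saturated chain carbon bound to a nitrogen on an aromatic ring gives a number 10 percentage points lower from compound 3 to compound 4 (within the scatter) and so provides the first single-change reading at this place. Furan-2-yl is not required for a measurable read-out here: a five-membered aromatic ring with 2 hetero atoms and 1 hydrogen-bond donor also gives a number, and the step cannot be told apart from repeat scatter. Nothing measured on these compounds speaks to the reason for this outcome.

Going by these compounds, whether an unsubstituted phenyl at this place would read like the furan-2-yl and 1H-imidazol-5-yl compounds remains open. So does the effect of a non-aromatic group there, such as a piperidine ring or a short chain ending in an amine or a carboxylic acid.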